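The source may hold more compounds than are shown below. What is called first, only, known or untested is meant among the compounds shown, and "the series" means these compounds.

Measured in a functional assay on Jurkat cells (Homo sapiens) for activation, with a stated time of 24 h; on this read-out lower numbers stand for an effect already at smaller amounts and higher numbers for an effect only at larger amounts of compound:
compound 1 `Oc1ccccc1CNc1ccc(-c2cccc(F)c2)cc1`: 2020 nM
compound 2 `Oc1cccc(-c2ccc(NCc3ccccc3O)cc2)c1`: "not active" (no number reported)

Compound 2 stands without a number: in this assay compound 2 is reported as "not active" (no number reported), while compound 1 reaches 2020 nM. Compound 3 `Oc1ccccc1CNc1ccc(-c2cccc(OC(F)(F)F)c2)cc1` differs from compound 2 by trifluoromethyl in place of hydrogen on an oxygen on an aromatic ring. Among the measured compounds shown here, no measured pair covers this change, so neither its size nor its direction in this assay can be read from the data; the only measured compound carrying another group at this place, compound 1, gives 2020 nM. Compound 3 is therefore expected near 3000 nM, within 800 nM to 15000 nM, with a real chance of again yielding no number.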

Compound 3, half-maximal effective concentration: "not active" (no number reported)
Nothing numeric was reported for compound 3; there is nothing to compare the estimate with.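

Compound 2 and compound 3 both stand without a number, so no step can be read between them. On these data alone, how far hydroxy to trifluoromethoxy shifts activity stays open, and no available evidence bears on this result.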